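The source may hold more compounds than are shown below. What is called first, only, known or untested is meant among the compounds shown, and "the series" means these compounds.

Compound 1 `CCn1c(C(=O)NCC(=O)OC)ccc1C(CC)(CC)c1ccc(OCS(=O)(=O)c2ccccc2)c(C)c1` carries an amide whose nitrogen bears a (methoxycarbonyl)methyl group. In a functional assay on PC-3 cells (Homo sapiens) for antiproliferative activity, read by MTT assay, with a stated time of 24 h (on this read-out lower numbers stand for stronger inhibition and higher numbers for weaker inhibition), compound 1 gives only a limit, > 50000 nM, and not a number. Its value therefore sits at the limit of > 50000 nM in this assay, at which 2 of the 3 values shown sit. Compound 2 `CCn1c(C(=O)NCCNC(=O)OC(C)(C)C)ccc1C(CC)(CC)c1ccc(OCS(=O)(=O)c2ccccc2)c(C)c1` also reaches only a limit in this assay, > 50000 nM. Compound 3 `CCn1c(C(=O)N[C@H](C)CO)ccc1C(CC)(CC)c1ccc(OCS(=O)(=O)c2ccccc2)c(C)c1` carries a 1-(hydroxymethyl)ethyl group on the amide-type nitrogen instead, and in this assay compound 3 gives 7790 nM. The step of an at least 6.4-fold lower number from compound 1 to compound 3 (0.80 log units; beyond the scatter) and the step of an at least 6.4-fold lower number from compound 2 to compound 3 (0.80 log units; beyond the scatter) both show that exchanging the (methoxycarbonyl)methyl or 2-((tert-butoxycarbonyl)amino)ethyl group for a short hydroxyl-bearing chain turned a bare limit into a readable number; the step that the two limits leave unreadable from compound 1 to compound 2 stays hidden between two limits.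

Compound 4 `CCn1c(C(=O)N[C@@H](CO)CCO)ccc1C(CC)(CC)c1ccc(OCS(=O)(=O)c2ccccc2)c(C)c1` has not yet been measured in this assay. It differs from compound 1 by 3-hydroxy-1-(hydroxymethyl)propyl in place of (methoxycarbonyl)methyl on an amide-type nitrogen. This change is of the same kind as the step of an at least 6.4-fold lower number from compound 1 to compound 3 (0.80 log units; beyond the scatter), a hydroxyl-bearing alkyl replacing the (methoxycarbonyl)methyl group, so a step of similar size toward stronger inhibition is expected here. The step of an at least 5.0-fold lower number from compound 1 to compound 4 (0.69 log units; beyond the scatter) is what this expectation amounts to. For compound 4 the expected value in this assay is 10000 nM, with a range from 3000 nM to 40000 nM.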

Compound 4, half-maximal inhibitory concentration: 14100 nM
Estimate against measurement, compound 4: 1.4-fold (0.15 log units) below; low and high end bracket the measured number.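

On the amide-type nitrogen, a second hydroxyl-bearing chain also gives a readable number in this assay, as the step of an at least 3.5-fold lower number from compound 1 to compound 4 (0.54 log units; beyond the scatter) and the step of an at least 3.5-fold lower number from compound 2 to compound 4 (0.54 log units; beyond the scatter) both show, so compound 3 no longer stands alone. Hydroxymethyl in place of hydrogen on the saturated chain carbon adds a further hydroxyl, yet the step of a 1.8-fold higher number from compound 3 to compound 4 (0.26 log units; within the scatter) cannot be told apart from no change, so on these compounds the second hydroxyl-bearing group shows no readable effect in either direction. Compound 1 and compound 2, both without a hydroxyl at this place, remain limits and not numbers: the limit of > 50000 nM in this assay, at which 2 of the 4 values shown sit.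

The groups leaving in these steps differ from the hydroxyl chains in more than the hydroxyl, since they also carry an ester or a carbamate, so the compounds shown cannot single out the hydroxyl as what separates a limit from a number. On these data alone, whether an amine or a carboxylic acid at the end of the chain would also give a readable number stays open, as does the effect of a longer chain or of the opposite configuration at the stereocentre.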